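The source may hold more compounds than are shown below. What is called first, only, known or untested is meant among the compounds shown, and "the series" means these compounds.

Three compounds of the shared core have been run in a functional assay on MCF7 cells (Homo sapiens) for cytotoxicity, read by sulforhodamine B assay, with a stated time of 48 h; on this read-out lower numbers stand for stronger inhibition of growth and higher numbers for weaker inhibition of growth. Compound 1 `COc1ccc(-c2ccc(C)n2-c2ccc(-c3nc4ccc(F)cc4s3)cc2)cc1` gives 2120 nM. Compound 2 `COc1ccc2nc(-c3ccc(-n4c(C)ccc4-c4ccc(C)cc4)cc3)sc2c1` gives 2570 nM, and compound 3 `COc1ccc2nc(-c3ccc(-n4c(C)ccc4-c4ccc(F)cc4)cc3)sc2c1` gives 2480 nM. Compound 3 sits within the scatter of both others, nearest to compound 2 and furthest from compound 1, so the three numbers do not separate from one another. Among the compounds with values here, the only step between measured compounds, a 1.0-fold lower number from compound 2 to compound 3 (0.02 log units; within the scatter), swaps a substituent on the pendant phenyl and leaves the number essentially unchanged. Compound 4 `COc1ccc(-c2ccc(C)n2-c2ccc(-c3nc4ccc(OC)cc4s3)cc2)cc1` differs from compound 3 by methoxy in place of fluoro on an aromatic carbon, a change at the same place that step touched. Compound 1 and compound 3 each carry one methoxy and one fluoro, on opposite rings, and their two values agree within the scatter, which points the same way. The step from compound 3 to compound 4 is therefore expected to stay within the scatter, with a 1.1-fold lower number from compound 3 to compound 4 (0.03 log units; within the scatter). Compound 4 is estimated at 2300 nM, in a range from 1200 nM to 4500 nM.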

Compound 4, concentration for 50% growth inhibition: 3090 nM
Beside the measured number, compound 4's estimate is 1.3-fold (0.13 log units) below it; measured number inside the range.
By their numbers in this assay, from the lowest: compounds 1, 3, 2 and 4 (each within the scatter of the next).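

In this assay, the position para to a large group now carries methyl, fluoro and methoxy with no separation among them: the 4-fluorophenyl to 4-methoxyphenyl change gives a 1.2-fold higher number from compound 3 to compound 4 (0.10 log units; within the scatter), and methoxy in place of methyl gives a 1.2-fold higher number from compound 2 to compound 4 (0.08 log units; within the scatter). The same swap of fluoro for methoxy at the other fluoro-bearing place also stays within the scatter, with a 1.5-fold higher number from compound 1 to compound 4 (0.16 log units; within the scatter), so this change has now been read at two places on the shared core without a step beyond the scatter. Nothing available explains this flat response.

As far as these compounds go, whether an amine, a carboxylic acid or a longer alkoxy chain at this position would move the number remains open. The compounds shown also leave open whether any change to the shared core can take a value beyond the scatter of these four.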